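Acyl Group Swap in an Aryl Sulfonate Anilide Series

This account rests on a few compounds, and the source may have more. Where it says the series, first, only, none or still open, it means among the compounds named here.

Measured in a functional assay on HT-1080 cells (Homo sapiens) for antiproliferative activity, read by sulforhodamine B assay, with a stated time of 48 h; on this read-out higher numbers stand for weaker inhibition and lower numbers for stronger inhibition:
compound 1 `CC(=O)Nc1ccc(S(=O)(=O)Oc2ccccc2C(C)C)cc1` gives 12000 nM
compound 2 `CCC(=O)Nc1ccc(S(=O)(=O)Oc2ccccc2C(C)C)cc1` gives 2100 nM
compound 3 `CC(C)c1ccccc1OS(=O)(=O)c1ccc(NC(=O)C(C)(C)C)cc1` gives 11000 nM

Among these three, compound 3 stands second highest on the numbers. Its nearest neighbour is compound 1, which sits within the scatter of it (a 1.1-fold lower number from compound 1 to compound 3 (0.04 log units; within the scatter)), while compound 2 lies well apart (a 5.2-fold higher number from compound 2 to compound 3 (0.72 log units; beyond the scatter)).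

Compound 4 `CC(C)c1ccccc1OS(=O)(=O)c1ccc(NC(=O)CCl)cc1` differs from compound 3 by chloromethyl in place of tert-butyl on a carbonyl carbon. Among the compounds with values here, two measured steps bear on this position on the carbonyl carbon. From compound 1 to compound 2 the ethyl group brought a 5.7-fold lower number from compound 1 to compound 2 (0.76 log units; beyond the scatter), a modest but clear improvement, whereas the tert-butyl group gave a 1.1-fold lower number from compound 1 to compound 3 (0.04 log units; within the scatter) against methyl and a 5.2-fold higher number from compound 2 to compound 3 (0.72 log units; beyond the scatter) against ethyl. So the only acyl group that moved the numbers beyond the scatter was ethyl, in compound 2. Within the data shown here, no measured compound carries a chlorine, so the chloromethyl group is uncharted here, and the expectation rests on the tert-butyl group leaving rather than on what enters. Compound 4 is thus expected to show a 2.8-fold lower number from compound 3 to compound 4 (0.44 log units; beyond the scatter), with some uncertainty. The estimate for compound 4 in this assay is 4000 nM, with a range from 1200 nM to 13000 nM.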

Compound 4, half-maximal inhibitory concentration: 1000 nM
The estimate for compound 4 lay 4.0-fold (0.60 log units) above the measured number; measured number outside the range, below it.
By their numbers in this assay, from the lowest: compound 4; then compound 2; then compounds 3 and 1 (each within the scatter of the next).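

In this assay, chloromethyl on the carbonyl carbon gives the lowest number of the four compounds, and the step to compound 4 lies beyond the scatter from each of the other acyl groups: tert-butyl (an 11-fold lower number from compound 3 to compound 4 (1.04 log units; beyond the scatter)), methyl (a 12-fold lower number from compound 1 to compound 4 (1.08 log units; beyond the scatter)) and ethyl (a 2.1-fold lower number from compound 2 to compound 4 (0.32 log units; beyond the scatter)). The earlier compounds shown here showed this position responding modestly at most, with ethyl alone standing apart, whereas chloro in place of hydrogen on the saturated chain carbon bound to the carbonyl carbon now gives a large step, against the modest one for methyl in place of hydrogen on that same carbon (a 5.7-fold lower number from compound 1 to compound 2 (0.76 log units; beyond the scatter)), and chloro in place of methyl still lowers the number beyond the scatter. The data shown offer no measurement that accounts for this gain.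

The compounds shown leave open whether the gain is tied to chlorine or would also appear with fluoromethyl, bromomethyl or dichloromethyl on the carbonyl carbon. They also leave open how an aminomethyl or methoxymethyl group would read at this position, and whether chloromethyl would give the same gain on a different core.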